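The source may report more compounds than this note shows. Statements on the series, on what has been measured and on what is new or still open speak of the compounds shown alone.

Measured in an ADME assay on BJ cells (Homo sapiens) for cytotoxicity, read by MTT assay, with a stated time of 72 h; a higher number here means that more compound is tolerated, a lower number that less compound is tolerated:
- Compound 1 `OC[C@H]1O[C@@H](n2cc(F)c3c(-c4ccccc4)ncnc32)[C@H](O)[C@@H]1O`: > 50000 nM (a limit of the assay, not a number)
- Compound 2 `OC[C@H]1O[C@@H](n2cc(F)c3c(-c4ccco4)ncnc32)[C@H](O)[C@@H]1O`: 310 nM (a measured number)
- Compound 3 `OC[C@H]1O[C@@H](n2cc(F)c3c(-c4ccoc4)ncnc32)[C@H](O)[C@@H]1O`: 350 nM (a measured number)

Compound 3 stands together with compound 2, as the gap between them lies within the scatter (a 1.1-fold higher number from compound 2 to compound 3 (0.05 log units; within the scatter)). Compound 1, with its phenyl group, stands apart at its limit. Swapping that phenyl for a furan gave large steps (an at least 160-fold lower number from compound 1 to compound 2 (2.20 log units; beyond the scatter)) and (an at least 140-fold lower number from compound 1 to compound 3 (2.15 log units; beyond the scatter)).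

Compound 4 `OC[C@H]1O[C@@H](n2cc(F)c3c(-c4cccs4)ncnc32)[C@H](O)[C@@H]1O` has thiophen-2-yl in place of furan-3-yl on an aromatic carbon. Both groups are five-membered aromatic rings with 1 hetero atom, so the change stays within the ring type of compound 2 and compound 3. Within the data shown here, no measured step exchanges oxygen for sulfur, so this remains an extrapolation. The closest guide is the small step between the two furans of compound 2 and compound 3 (a 1.1-fold higher number from compound 2 to compound 3 (0.05 log units; within the scatter)), not the large steps away from phenyl. No change beyond the scatter is therefore expected in this assay, in either direction. The expected step is small (a 1.2-fold lower number from compound 3 to compound 4 (0.07 log units; within the scatter)). The estimate for compound 4 is 300 nM (estimated range 100 nM to 1000 nM).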

Compound 4, half-maximal cytotoxic concentration: 170 nM
Beside the measured number, compound 4's estimate is 1.8-fold (0.25 log units) above it; the measured number falls inside the stated range.
By their numbers in this assay, from the lowest: compounds 4, 2 and 3 (each within the scatter of the next, the first and the last beyond it). At a limit, above all of these: compound 1.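

Thiophen-2-yl, whose ring holds sulfur, follows the two furans in this assay, so the large step away from phenyl is not limited to oxygen-containing rings at this position: [ an at least 290-fold lower number from compound 1 to compound 4 (2.46 log units; beyond the scatter) ]. For compound 1, the value is a limit of the assay and not a number: the limit of > 50000 nM in this assay, at which 1 of the 4 values shown sits.

Among the five-membered rings, the change gives the first modest step beyond the scatter, [ a 2.1-fold lower number from compound 3 to compound 4 (0.31 log units; beyond the scatter) ], yet compound 4 cannot be told apart from the other furan, [ a 1.8-fold lower number from compound 2 to compound 4 (0.26 log units; within the scatter) ], so the effect of this swap is small and depends on which furan is the starting point.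

Thiophen-3-yl would show whether the attachment point of a sulfur ring matters as little as it does for the furans. On these data alone, how a pyridine ring, an amine or a longer chain would behave at this place stays open.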